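Extending the amino chain on the shared core

The source may hold more compounds than are shown below. What is called first, only, known or untested is meant among the compounds shown, and "the series" means these compounds.

Compound 1 `CNc1nc2c(SCc3ccccc3)ncnc2n1C1O[C@H](CO)[C@@H](O)[C@H]1O` sits at the weak end of the three measurements in an assay on cell membranes for binding affinity to Equilibrative nucleoside transporter 1 (Homo sapiens); on this read-out higher numbers stand for weaker inhibition and lower numbers for stronger inhibition: compound 1 gives 28 nM. Compound 2 `CCCNc1nc2c(SCc3ccccc3)ncnc2n1C1O[C@H](CO)[C@@H](O)[C@H]1O` gives 5.3 nM and compound 3 `CCCCNc1nc2c(SCc3ccccc3)ncnc2n1C1O[C@H](CO)[C@@H](O)[C@H]1O` gives 5.4 nM. Compound 4 `CCCCCCNc1nc2c(SCc3ccccc3)ncnc2n1C1O[C@H](CO)[C@@H](O)[C@H]1O` differs from compound 1 by pentyl in place of hydrogen on a saturated chain carbon bound to a nitrogen on an aromatic ring. Within the data shown here, the steps that bear on this change are a 5.3-fold lower number from compound 1 to compound 2 (0.72 log units; beyond the scatter) and a 5.2-fold lower number from compound 1 to compound 3 (0.71 log units; beyond the scatter), whereas a 1.0-fold higher number from compound 2 to compound 3 (0.01 log units; within the scatter). Lengthening the chain past propyl therefore added nothing further within these three compounds. For compound 4 a step of about a 5.1-fold lower number from compound 1 to compound 4 (0.71 log units; beyond the scatter) is expected, in the same direction as the steps to compound 2 and compound 3. Compound 4 is estimated at 5.5 nM in this assay, with a range from 2 nM to 16 nM.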

Compound 4, inhibition constant: 3.7 nM
Estimate against measurement, compound 4: 1.5-fold (0.17 log units) above, within the range that was stated.
By their numbers in this assay, from the lowest: compounds 4, 2 and 3 (each within the scatter of the next); then compound 1.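

Hexylamino keeps the gain over methylamino, with a 7.6-fold lower number from compound 1 to compound 4 (0.88 log units; beyond the scatter), but the longer chain brings no further change beyond the scatter, with a 1.5-fold lower number from compound 3 to compound 4 (0.16 log units; within the scatter) and a 1.4-fold lower number from compound 2 to compound 4 (0.16 log units; within the scatter). At this position, the ethyl change counts for less on a longer chain than on compound 1: the same change on two cores in this assay, a 5.3-fold lower number (0.72 log units; beyond the scatter) from compound 1 to compound 2 and a 1.5-fold lower number (0.16 log units; within the scatter) from compound 3 to compound 4, 3.6-fold (0.56 log units) apart, beyond the scatter of two such steps. The propyl change shows the same dependence on the starting chain: the same change on two cores in this assay, a 5.2-fold lower number (0.71 log units; beyond the scatter) from compound 1 to compound 3 and a 1.4-fold lower number (0.16 log units; within the scatter) from compound 2 to compound 4, 3.6-fold (0.56 log units) apart, beyond the scatter of two such steps.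

Still open, from the compounds shown here alone, is whether an octyl or longer chain stays within the scatter of compound 4, and how an amine or carboxylic acid carried on the chain would read.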